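The source may hold more compounds than are shown below. What is called first, only, known or untested is meant among the compounds shown, and "the series" means these compounds.

Values in a functional assay on NALM-6 cells (Homo sapiens) for cytotoxicity, with a stated time of 72 h (on this read-out higher numbers stand for an effect only at larger amounts of compound and lower numbers for an effect already at smaller amounts), for the measured compounds:

Compound 1, `C=C[C@@](C)(/C=C/c1ccc(OS(=O)(=O)C(F)(F)F)cc1)CCC=C(C)C`: > 43400 nM.
Compound 2, `C=C[C@@](C)(/C=C/c1ccc(OS(=O)(=O)c2ccc(C)cc2)cc1)CCC=C(C)C`: > 43400 nM.
Compound 3, `C=C[C@@](C)(/C=C/c1ccc(Nc2cc(C(F)(F)F)cc(C(F)(F)F)c2)cc1)CCC=C(C)C`: > 43400 nM.

Every one of these three values is a limit of the assay, not a number. Compound 1 therefore stands only at that limit, and compound 2 and compound 3 stand in the same place (the limit of > 43400 nM in this assay, at which 3 of the 3 values shown sit). Within the data shown here, the one measured step, a step that the two limits leave unreadable from compound 1 to compound 2, puts a 4-methylphenyl in place of trifluoromethyl on a sulfonyl sulfur, and its size cannot be read because the limit of > 43400 nM in this assay, at which 3 of the 3 values shown sit, holds both of its ends. Compound 3 adds a third structure without a numbered value.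

Compound 4, `C=C[C@@](C)(/C=C/c1ccc(-c2cccc(F)c2)cc1)CCC=C(C)C`, has not yet been measured. Compared with compound 1, (3-fluorophenyl in place of ((trifluoromethyl)sulfonyl)oxy on an aromatic carbon). Among the measured compounds shown here, no measured step with a readable size bears on this change, so there is nothing to say about its direction beyond the observation that all three measured compounds sit at the same limit. For compound 4 the expected value in this assay is 40000 nM, within a range from 8000 nM to 100000 nM. That estimate corresponds to an expected step of an at least 1.0-fold lower number from compound 1 to compound 4 (0.03 log units; that floor lies within the scatter), which is expected to be no change beyond the scatter, with a fair chance that only a limit is reported again.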

Compound 4, half-maximal effective concentration: > 43400 nM
Compound 4 was reported as a limit (the forecaster's own chance of this, stated with the estimate: 65%); at least 1.0-fold (0.03 log units) between middle value and limit.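

Compound 4 also gives a limit rather than a number, so the step from compound 1 to compound 4 cannot be read, as both of its ends sit at the same place: the limit of > 43400 nM in this assay, at which 4 of the 4 values shown sit.

The compounds shown leave open how these groups on the aromatic ring truly compare, and whether any change to the shared core gives a numbered value in this assay.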